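The compounds below may be only part of what the source reports. "The series", "measured", "known", "first", "only" and "open" are said of these compounds alone.

Measured in a functional assay on Daoy cells (Homo sapiens) for cytotoxicity, read by MTT assay, with a stated time of 72 h; on this read-out lower numbers stand for stronger inhibition and higher numbers for weaker inhibition:
Compound 1, `COc1cc(N(C)C(=O)c2cccc(F)c2)cc(OC)c1OC`: >= 125000 nM, a limit of the assay.
Compound 2, `COc1cc(NC(=O)Nc2ccc([N+](=O)[O-])cc2)cc(OC)c1OC`: 70800 nM.
Compound 3, `COc1cc(N(C)C(=O)c2ccc(F)cc2)cc(OC)c1OC`: >= 125000 nM, a limit of the assay.

Compound 3 thus stands at a limit, namely (the limit of >= 125000 nM in this assay, at which 2 of the 3 values shown sit). The move from compound 1 to compound 3, a step that the two limits leave unreadable from compound 1 to compound 3, gives no readable size. Compound 4, `COc1ccc(C(=O)N(C)c2cc(OC)c(OC)c(OC)c2)cc1`, differs from compound 3 by methoxy in place of fluoro on an aromatic carbon; cut one bond further out this reads 4-fluorophenyl to 4-methoxyphenyl. No measured step touches this position in a readable way, so neither size nor direction of the change in this assay can be taken from the numbers shown. The step from compound 3 to compound 4 is expected to be an at least 2.0-fold lower number from compound 3 to compound 4 (0.31 log units; beyond the scatter). Compound 4 is expected near 60000 nM, within 15000 nM to 200000 nM, with a fair chance of another limit.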

Compound 4, half-maximal inhibitory concentration: >= 125000 nM
Compound 4 gave a limit, no number; the forecaster's own chance of this, stated with the estimate: 40%; middle value at least 2.0-fold (0.31 log units) away from the limit.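

Compound 4 joins compound 1 and compound 3 at a limit in this assay, so no step among these compounds can be read: the limit of >= 125000 nM in this assay, at which 3 of the 4 values shown sit.

From the compounds shown here alone, whether 3-fluorophenyl, 4-fluorophenyl and 4-methoxyphenyl differ at all in this assay stays open.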